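A Pyridine in Place of an Oxazole on the Amide Nitrogen

The source may hold more compounds than are shown below. What is called first, only, known or untested is meant among the compounds shown, and "the series" means these compounds.

Compound 1, `Cc1ccc(OCC(=O)N(Cc2cccs2)c2ncco2)cc1`: 0.3 nM
Compound 2, `CCN(Cc1cccs1)C(=O)COc1ccc2c(c1)CCC2`: 0.8 nM
Compound 3, `CCN(Cc1cccs1)C(=O)COc1ccc2c(c1)COC2`: 61 nM

All three compounds were tested in an assay on HEK293 cells for agonist activity at transient receptor potential cation channel subfamily M member 8 (Homo sapiens), read by fluorescence and calcium flux, with a stated time of 15 min; a higher number here means that more compound is needed for the effect, a lower number that less compound is needed. Compound 1 gives the lowest number of the three; compound 2 comes nearest, and its number is already beyond the usual scatter, while compound 3 stands far above both. Compound 2 and compound 3 differ from compound 1 in more than one place, so their numbers can only be compared as they stand, not traced to a single change.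

Compound 4, `Cc1ccc(OCC(=O)N(Cc2cccs2)c2ccncc2)cc1`, has not yet been measured in this assay. It keeps the whole of compound 1 except for one change: pyridin-4-yl in place of 1,3-oxazol-2-yl on an amide-type nitrogen. Within the data shown here, no pair of measured compounds differs in this position alone, so there is nothing here that shows how this assay responds to such a swap. A change of the aromatic group directly on the amide nitrogen is not a small one, and a moderate step toward a higher number, beyond the scatter, seems the more likely outcome, though a result close to compound 1 cannot be ruled out. For compound 4 the expected step is a 10-fold higher number from compound 1 to compound 4 (1.00 log units; beyond the scatter). Compound 4 is estimated at 3 nM in this assay, within a range from 0.3 nM to 30 nM.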

Compound 4, half-maximal effective concentration: 52 nM
Compound 4: the middle estimate sits 17-fold (1.24 log units) below what was measured; the measured number lies above the stated range.
By their numbers in this assay, from the lowest: compound 1; then compound 2; then compounds 4 and 3 (each within the scatter of the next).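

In this assay, putting pyridin-4-yl in place of 1,3-oxazol-2-yl on the amide-type nitrogen gives a 170-fold higher number from compound 1 to compound 4 (2.24 log units; beyond the scatter) with the rest of the molecule unchanged. Among these compounds, this is the only pair here that differs in one place, and it shows that the assay is highly sensitive to which aromatic ring sits at this position. The change replaces one five-membered aromatic ring with 2 hetero atoms by one six-membered aromatic ring with 1 hetero atom, but no measurement of any property of these groups accompanies the result, so the step remains an observation without an explanation.

Since ring size and the number of hetero atoms change together in this swap, the pair cannot separate them, and phenyl or 1,3-thiazol-2-yl on the same nitrogen would give further points of comparison. On these data alone, it also remains open how a non-aromatic group such as cyclopropyl would fare at this position with the rest of compound 1 kept in place.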